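This account rests on a few compounds, and the source may have more. Where it says the series, first, only, none or still open, it means among the compounds named here.

Compound 2 `COc1ccc(/C(=C\c2cn(C(C)=O)c3ccc(OCc4ccccc4)cc23)C(=O)O)cc1OC` is one of two measured members of this series, the other being compound 1 `COc1ccc(OC)c(/C(=C\c2cn(C(C)=O)c3ccc(OCc4ccccc4)cc23)C(=O)O)c1`. In a functional assay on LNCaP cells (Homo sapiens) for cytotoxicity, read by MTT assay, with a stated time of 72 h (on this read-out higher numbers stand for weaker inhibition and lower numbers for stronger inhibition), compound 1 gives 44100 nM. For compound 2 this assay reports no number but only a limit, > 100000 nM, so that compound 2 stands at the limit of > 100000 nM in this assay, at which 1 of the 2 values shown sits. For the measured compounds named here, the only measured step in this assay, an at least 2.2-fold higher number from compound 1 to compound 2 (0.35 log units; beyond the scatter), ran upward to that limit.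

Compound 3 `COc1cc(OC)cc(/C(=C\c2cn(C(C)=O)c3ccc(OCc4ccccc4)cc23)C(=O)O)c1` differs from compound 2 in one place: 3,5-dimethoxyphenyl in place of 3,4-dimethoxyphenyl on a double-bonded chain carbon bound to a carbonyl carbon and a double-bonded chain carbon. Going by the values given here, no measured step tests the exchange of 3,4-dimethoxyphenyl for 3,5-dimethoxyphenyl. Among the compounds with values here, the single step in this assay, an at least 2.2-fold higher number from compound 1 to compound 2 (0.35 log units; beyond the scatter), shows only that rearranging the two methoxy groups on this phenyl can shift the number by a modest but measurable amount, and compound 2 already sits at the limit. Compound 3 is therefore expected to remain near that limit, with a number no higher from compound 2 to compound 3 (the limit leaves the size open) as the expected step in this assay. The estimate for compound 3 in this assay is 100000 nM, within a range of 40000 nM to 300000 nM.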

Compound 3, half-maximal inhibitory concentration: 26100 nM
Beside the measured number, compound 3's estimate is 3.8-fold (0.58 log units) above it; measured number outside the range, below it.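

In this assay, the 3,5-dimethoxyphenyl in place of 3,4-dimethoxyphenyl, on a double-bonded chain carbon bound to a carbonyl carbon and a double-bonded chain carbon, gives an at least 3.8-fold lower number from compound 2 to compound 3 (0.58 log units; beyond the scatter). The earlier pair showed only a rise to the limit on going from 2,5-dimethoxyphenyl to 3,4-dimethoxyphenyl; this step shows that the same atoms, joined differently, also lead away from that limit, so that among these three compounds compound 2, with its 3,4-dimethoxyphenyl, is the one that stands apart as the weakest. The 2,5-dimethoxyphenyl and 3,5-dimethoxyphenyl compounds are not separated, with a 1.7-fold lower number from compound 1 to compound 3 (0.23 log units; within the scatter).

How large the step to compound 3 really is stays open, since compound 2 has a limit and not a number: the limit of > 100000 nM in this assay, at which 1 of the 3 values shown sits. Nor do the compounds shown tell how a phenyl bearing a single methoxy group, a hydroxyl group or a chlorine atom would read at this place in this assay, or how a methyl ester or a primary amide would read in place of the carboxylic acid.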